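One Added Chain Carbon on Compound 2

This account rests on a few compounds, and the source may have more. Where it says the series, first, only, none or still open, it means among the compounds named here.

Going by the values given here, in a functional assay (strain AB) with Danio rerio as the target, read by microscopy, with a stated time of 1 h (a lower number here means that less compound is needed, a higher number that more compound is needed for the effect), compound 2 `CC(C)(C)OC(=O)CCN1CCc2c(sc(NC(=O)Nc3ccc(Cl)cc3)c2C(N)=O)C1` gives 1100 nM, the lower of the two actual numbers so far. Compound 1 `CCN1CCc2c(sc(NC(=O)Nc3cccc(Cl)c3Cl)c2C(N)=O)C1` gives 17400 nM, a gap beyond the scatter. Compound 3 `CCN1CCc2c(sc(NC(=O)Nc3ccc(Cl)cc3)c2C(=O)OC)C1` reads > 25000 nM, which is a limit and not a number.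

Compound 4 `CC(C)(C)OC(=O)CCCN1CCc2c(sc(NC(=O)Nc3ccc(Cl)cc3)c2C(N)=O)C1` differs from compound 2 in one place: (tert-butoxycarbonyl)methyl in place of tert-butoxycarbonyl on a saturated chain carbon, two bonds along the chain from an amine nitrogen in a ring. Its 3-(tert-butoxycarbonyl)propyl stands where compound 2 has 2-(tert-butoxycarbonyl)ethyl. Among the compounds with values here, no measured pair shows this change, so the expectation rests on compound 2 and its 1100 nM. The expected change is a 1.2-fold higher number from compound 2 to compound 4 (0.07 log units; within the scatter), which means no step beyond the scatter in this assay. Compound 4 is estimated at 1300 nM, within an expected range of 450 nM to 4000 nM.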

Compound 4, half-maximal effective concentration: 560 nM
Compound 4: the middle estimate sits 2.3-fold (0.37 log units) above what was measured; the range from low to high includes it.
By their numbers in this assay, from the lowest: compounds 4 and 2 (each within the scatter of the next); then compound 1. At a limit, above all of these: compound 3.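

In this assay, going from 2-(tert-butoxycarbonyl)ethyl to 3-(tert-butoxycarbonyl)propyl gives a 2.0-fold lower number from compound 2 to compound 4 (0.29 log units; within the scatter) and so makes no real difference. Going by these compounds alone, this is the first comparison that differs in one place only, and it shows that this chain can carry one more carbon without leaving the scatter. Nothing measured here explains why the added carbon matters so little.

Going by these compounds, whether a longer chain would read the same stays open. So does the effect of a carboxylic acid or an amine in place of tert-butoxycarbonyl at the chain end.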